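The source may hold more compounds than are shown below. What is called first, only, known or untested is meant among the compounds shown, and "the series" means these compounds.

Working notes on the series.

Compound 3 `NS(=O)(=O)OC[C@@H]1C[C@@H](n2nnc3c(Nn4ccc5ccccc54)ncnc32)C[C@@H]1O` carries a 1H-indol-1-yl group on a nitrogen on an aromatic ring of the shared core. In an assay on a protein complex for inhibition of NEDD8 activating enzyme (Homo sapiens), read by HTRF, with a stated time of 2 h, in the presence of a further agent that is not named here (a higher number here means a weaker inhibitor, a lower number a stronger inhibitor), compound 3 gives only a limit, > 10000 nM. Compound 1 `NS(=O)(=O)OC[C@@H]1C[C@@H](n2nnc3c(NC4CCCC4)ncnc32)C[C@@H]1O` bears cyclopentyl at the same place; in this assay compound 1 gives a limit as well, > 10000 nM. Compound 2 `NS(=O)(=O)OC[C@@H]1C[C@@H](n2nnc3c(Nc4n[nH]c5ccccc45)ncnc32)C[C@@H]1O` bears 1H-indazol-3-yl there; in this assay compound 2 also gives a limit, > 10000 nM. Hence the step that the two limits leave unreadable from compound 1 to compound 3 is unreadable, as are a step that the two limits leave unreadable from compound 1 to compound 2 and a step that the two limits leave unreadable from compound 2 to compound 3. Where compound 3 stands is therefore known only as a limit, and the same holds for the other two values, all three sitting at the limit of > 10000 nM in this assay, at which 3 of the 3 values shown sit.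

Compound 4 `NS(=O)(=O)OC[C@@H]1C[C@@H](n2nnc3c(N[C@@H]4c5ccccc5C[C@@H]4O)ncnc32)C[C@@H]1O` differs from compound 3 by a group of 10 heavy atoms (9 carbon, 1 oxygen; one five-membered non-aromatic ring of carbon only, one six-membered aromatic ring of carbon only) in place of a group of 9 heavy atoms (8 carbon, 1 nitrogen; one five-membered aromatic ring with 1 hetero atom, one six-membered aromatic ring of carbon only), on a nitrogen on an aromatic ring. Among the compounds with values here, none of the measured steps gives a readable size, so no step carries over to this change; the group entering differs from all three groups measured so far in that it brings a non-aromatic ring and a hydrogen-bond donor.

With three limits and no readable step, the expectation for compound 4 is set loosely: in this assay compound 4 is estimated at 3000 nM, with a range from 300 nM to 10000 nM. The step of an at least 3.3-fold lower number from compound 3 to compound 4 (0.52 log units; beyond the scatter) is thus an estimate only, and a further limit cannot be ruled out.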

Compound 4, half-maximal inhibitory concentration: 2.28 nM
The estimate for compound 4 lay 1300-fold (3.12 log units) above the measured number; measured number outside the range, below it.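

The nitrogen on an aromatic ring of the shared core is now shown to be a place that can decide the result in this assay: the group in compound 4 gives an at least 4300-fold lower number from compound 3 to compound 4 (3.64 log units; beyond the scatter), and likewise an at least 4300-fold lower number from compound 2 to compound 4 (3.64 log units; beyond the scatter) and an at least 4300-fold lower number from compound 1 to compound 4 (3.64 log units; beyond the scatter). These three steps are large but open on one side, and their full size cannot be given, as each starts from a compound known only as a limit: the limit of > 10000 nM in this assay, at which 3 of the 4 values shown sit. Within the data shown here, the steps among compounds 1, 2 and 3 cannot be read, so those three groups remain unordered, and compound 4 is the first to show that the shared core can carry a measured number in this assay.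

The entering group differs from each earlier group in more than one respect, with a non-aromatic ring, a hydrogen-bond donor and 2 defined stereocentres, so the shown compounds do not tell which of these features goes with the step. The same group without its oxygen, the same group with its stereocentres inverted, or a benzyl group at this place would bear directly on that question.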